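The source may report more compounds than this note shows. Statements on the series, on what has been measured and on what is new or still open speak of the compounds shown alone.

Compound 1 `O=C(Nc1ccc(-c2cscn2)cc1)C1CCN(Cc2ccc(F)c(F)c2)C1` gives 8000 nM in a functional assay on A-375 cells (Homo sapiens) for activation, with a stated time of 3 days; a lower number here means that less compound is needed, a higher number that more compound is needed for the effect.
Compound 2 `O=C(Nc1ccc(-c2cscn2)cc1)C1CCCN(Cc2cccc(F)c2F)C1` gives 10000 nM in this assay.
Compound 3 `O=C(Nc1ccc(-c2ccccc2)cc1)C1CCCN(Cc2ccc(F)c(F)c2)C1` gives 5000 nM in this assay.

All three measured compounds share a core built from an amide linking a substituted aniline to a saturated nitrogen ring that carries a fluorinated benzyl group. They differ in the ring size of that saturated ring, in the placement of the fluorine atoms, and in the aromatic group sitting on the aniline. Compound 3 gives the lowest of the three numbers, but its gaps to compound 1 and to compound 2 both fall within the usual scatter of this kind of measurement, so the three compounds cannot be told apart on these data.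

Compound 4 `O=C(Nc1ccc(-c2ccco2)cc1)C1CCCN(Cc2ccc(F)c(F)c2)C1` has not yet been measured. It is built from compound 3 by one change: furan-2-yl in place of phenyl on an aromatic carbon. Going by the values given here, no pair of measured compounds isolates a change of this kind, so there is no measured step to lean on. Given that the three known numbers sit close together, the estimated step of a 1.2-fold higher number from compound 3 to compound 4 (0.08 log units; within the scatter) is expected to stay within the scatter, with no clear direction. Compound 4 is therefore expected to give about 6000 nM in this assay, with a range from 2000 nM to 20000 nM.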

Compound 4, half-maximal effective concentration: 2200 nM
The estimate for compound 4 lay 2.7-fold (0.44 log units) above the measured number; low and high end bracket the measured number.
By their numbers in this assay, from the lowest: compound 4; then compounds 3, 1 and 2 (each within the scatter of the next).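

Placing furan-2-yl in place of phenyl on the aromatic carbon para to a large group gives, in this assay, a 2.3-fold lower number from compound 3 to compound 4 (0.36 log units; beyond the scatter), the only step here that isolates one change. It shows that this position responds to the group it carries, something the first compounds could not show, since they differ from one another in more than one place and their numbers lie within the scatter. The change replaces a six-membered carbon ring with a five-membered ring holding one oxygen and one hydrogen-bond acceptor, but no measurement shown explains the lower number, and this single pair cannot separate the ring size from the oxygen.

Going by these compounds alone, whether the step would hold with another saturated ring or a different fluorine placement remains open, as only one pair tests it and only on the scaffold of compound 3. Also open, on these data alone, is how the number would respond at this position to other groups, such as thiophene, pyrrole, an amine or a carboxylic acid, so the limits of what this position accepts are still unknown.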